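Epoxide epimer of the carbamate series: expected activity

This account rests on a few compounds, and the source may have more. Where it says the series, first, only, none or still open, it means among the compounds named here.

Measured so far:
- compound 1 `CO[C@@H]1[C@H](OC(=O)N[C@@H](C(N)=O)C(C)(C)O)CC[C@]2(CO2)[C@H]1[C@@]1(C)O[C@@H]1C[C@@H]1OC1(C)C` gives 11.7 nM
- compound 2 `CO[C@@H]1[C@H](OC(=O)N[C@@H](C(N)=O)C(C)C)CC[C@]2(CO2)[C@H]1[C@@]1(C)O[C@@H]1C[C@H]1OC1(C)C` gives 1.3 nM

Both values come from an assay on isolated protein for inhibition of methionine aminopeptidase 2 (Homo sapiens), read by MTT assay; on this read-out lower numbers stand for an effect already at smaller amounts and higher numbers for an effect only at larger amounts of compound. For the measured compounds named here, compound 2 has the lowest number of the two; the only other measured compound, compound 1, sits at a higher number, and that gap is beyond the usual scatter. Going by the values given here, compound 1 and compound 2 differ in more than one respect, so their values show only that compound 2 is the stronger of the pair, not which change carries the gap.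

The step under consideration leads to compound 3 `CO[C@@H]1[C@H](OC(=O)N[C@@H](C(N)=O)C(C)C)CC[C@]2(CO2)[C@H]1[C@@]1(C)O[C@@H]1C[C@@H]1OC1(C)C`. It differs from compound 2 as follows: the two compounds have the same atoms and bonds and differ only in configuration as drawn: 1 of 8 stereo elements differ; a stereocentre at a saturated ring carbon is drawn R in compound 2 and S in compound 3. The remaining stereo elements and the whole framework are unchanged.

Among the compounds with values here, no step between measured compounds isolates this inversion alone, so its effect is uncertain. Compound 3 shares at that carbon the configuration drawn for compound 1, and compound 1 gives 11.7 nM, which leaves open a weakening beyond the scatter. For compound 3 the step is estimated as a 3.8-fold higher number from compound 2 to compound 3 (0.59 log units; beyond the scatter), towards a higher number. Compound 3 is therefore expected at 5 nM, with a range from 1.5 nM to 25 nM in this assay.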

Compound 3, half-maximal effective concentration: 6.5 nM
Compound 3: middle estimate off by 1.3-fold (0.11 log units), on the low side; low and high end bracket the measured number.
By their numbers in this assay, from the lowest: compound 2; then compounds 3 and 1 (each within the scatter of the next).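

Working notes on the stereocentre at the saturated ring carbon: in this assay, inversion from the R to the S drawing now stands alone as a single change, and it reads as a 5.0-fold higher number from compound 2 to compound 3 (0.70 log units; beyond the scatter). This configuration therefore counts in its own right in this series, and the gap belongs to the inversion and to nothing else in the structure, because of how the pair is related: the fact that compounds 2 and 3 differ only in the configuration as drawn. With the S drawing held fixed, hydrogen in place of hydroxy on a saturated chain carbon bound to three saturated chain carbons gives a 1.8-fold lower number from compound 1 to compound 3 (0.26 log units; within the scatter), so in this setting the exchange of hydroxy for hydrogen has no readable effect.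

Still open is whether that exchange stays as small under the R drawing, since the compounds shown carry only hydrogen at that chain carbon when the ring carbon is drawn R. Also open is how an amine, a carboxylic acid or a longer chain at that same chain carbon would read under either configuration.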